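Swapping a Dichlorophenyl for a Methylphenyl on the Amine

The source may report more compounds than this note shows. Statements on the series, on what has been measured and on what is new or still open speak of the compounds shown alone.

Two close relatives of one core have been measured in a functional assay, with a stated time of 6 min; a lower number here means a stronger inhibitor, a higher number a weaker inhibitor. Compound 1 `S=c1oc(-c2ccc3c(c2)OCCO3)nn1CNc1cc(Cl)ccc1Cl` gives 5420 nM, and compound 2 `S=c1oc(-c2ccc3c(c2)OCCO3)nn1CNc1ccc(Cl)c(Cl)c1` gives 6840 nM, which is the higher of the two numbers; the step of a 1.3-fold higher number from compound 1 to compound 2 (0.10 log units; within the scatter) lies within the scatter. The next compound, compound 3 `Cc1ccc(NCn2nc(-c3ccc4c(c3)OCCO4)oc2=S)cc1`, differs from compound 2 in one place: 4-methylphenyl in place of 3,4-dichlorophenyl on an amine nitrogen. Within the data shown here, no measured step covers this change; the only step known, a 1.3-fold higher number from compound 1 to compound 2 (0.10 log units; within the scatter), moved two dichlorophenyl patterns without effect beyond the scatter. A step of roughly a 1.2-fold higher number from compound 2 to compound 3 (0.07 log units; within the scatter) is therefore expected, with no clear direction. Compound 3 is estimated at 8000 nM, between 3000 nM and 22000 nM.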

Compound 3, half-maximal inhibitory concentration: 5700 nM
Compound 3: middle estimate off by 1.4-fold (0.15 log units), on the high side, within the range that was stated.
By their numbers in this assay, from the lowest: compounds 1, 3 and 2 (each within the scatter of the next).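

In this assay the 4-methylphenyl group gives a 1.2-fold lower number from compound 2 to compound 3 (0.08 log units; within the scatter) and a 1.1-fold higher number from compound 1 to compound 3 (0.02 log units; within the scatter). The earlier pair compared only two dichlorophenyl patterns, whereas this result shows that a ring with a methyl group and no chlorine on the amine nitrogen also stays within the scatter of both dichlorophenyl compounds. No other measurement here bears on this result.

Still open, as far as these compounds go, is whether any group at this position would move the number beyond the scatter. An unsubstituted phenyl, a methoxyphenyl or a saturated cyclohexyl ring on the amine nitrogen could help answer that.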